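Cytotoxicity Limits for Three Analogues and a Thiophene Variant

This account rests on a few compounds, and the source may have more. Where it says the series, first, only, none or still open, it means among the compounds named here.

Compound 1 `Cc1nc(C)c([C@H](OC(C)(C)C)C(=O)O)c(N2CCC(C)(C)CC2)c1-c1ccc(Cc2ccccc2)cc1`: in a toxicity assay on MT2 cells (Homo sapiens) for cytotoxicity, read by XTT assay, with a stated time of 4 days (a higher number here means that more compound is tolerated, a lower number that less compound is tolerated), compound 1 gives >= 20000 nM, which is a limit of the assay.
Compound 2 `COc1ccc(CCOc2ccc(-c3c(C)nc(C)c([C@H](OC(C)(C)C)C(=O)O)c3N3CCC(C)(C)CC3)cc2)cc1`: compound 2 gives >= 33500 nM, again a limit.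
Compound 3 `Cc1cc(CCOc2ccc(-c3c(C)nc(C)c([C@H](OC(C)(C)C)C(=O)O)c3N3CCC(C)(C)CC3)cc2)ccc1F`: compound 3 gives >= 33500 nM, also a limit.

Among the compounds with values here, compound 3 therefore stands only at a limit, shared with compound 2, as the limit of >= 33500 nM in this assay, at which 2 of the 3 values shown sit, shows, while the limit of >= 20000 nM in this assay, at which 1 of the 3 values shown sits, marks the single remaining value. The steps a step that the two limits leave unreadable from compound 1 to compound 3 and a step that the two limits leave unreadable from compound 2 to compound 3 give no readable size, so no direction can be taken from them. Compound 4 `Cc1ccc(CCOc2ccc(-c3c(C)nc(C)c([C@H](OC(C)(C)C)C(=O)O)c3N3CCC(C)(C)CC3)cc2)s1` carries the change (5-methylthiophen-2-yl in place of 4-fluoro-3-methylphenyl on a saturated chain carbon, two bonds along the chain from an oxygen on an aromatic ring). Nothing measured here points to a step beyond the scatter; compound 4 is expected to sit again at a limit, with an estimated step of a number no higher from compound 3 to compound 4 (the limit leaves the size open). The estimate for compound 4 is 33500 nM, ranging from 15000 nM to 70000 nM.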

Compound 4, half-maximal cytotoxic concentration: >= 25000 nM
Compound 4 ended at the assay's limit (the forecaster's own chance of this, stated with the estimate: 85%); the middle value lies beyond the limit too.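

Compound 4, like compound 1, compound 2 and compound 3, stands only at a limit, so no step among these four compounds can be read. The compounds shown leave open where each true cytotoxic concentration lies, and whether the changed groups affect it.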